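A few compounds are considered here, and "the series" means these few. Any claim that something is new, unique, unknown or untested is made for them only; others in the source may bear on it.

Compound 1, `Cc1ccc(OCC(=O)NNC(=O)c2cc3ccccc3oc2=O)c(C(=O)c2cccc(Cl)c2)c1`: 67300 nM
Compound 2, `Cc1ccc(OCC(=O)NNC(=O)c2cc3ccccc3oc2=O)c(C(=O)c2ccccc2Cl)c1`: 48400 nM
Compound 3, `Cc1ccc(OCC(=O)NNC(=O)c2cc3ccccc3oc2=O)c(C(=O)c2ccc(Br)cc2)c1`: 91100 nM

In a functional assay on Ehrlich cells (Mus musculus) for cytotoxicity, read by trypan blue exclusion, with a stated time of 48 h (a lower number here means a stronger inhibitor, a higher number a weaker inhibitor), compound 2 gives the lowest number of the three, though this standing is weak: the step of a 1.4-fold lower number from compound 1 to compound 2 (0.14 log units; within the scatter) and the step of a 1.9-fold higher number from compound 2 to compound 3 (0.27 log units; within the scatter) both lie within the scatter, as does the step of a 1.4-fold higher number from compound 1 to compound 3 (0.13 log units; within the scatter). On these numbers the three measured compounds cannot be told apart.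

Compound 4, `Cc1ccc(OCC(=O)NNC(=O)c2cc3ccccc3oc2=O)c(C(=O)c2ccc(F)cc2)c1`, differs from compound 2 in one place: 4-fluorophenyl in place of 2-chlorophenyl on a carbonyl carbon. The measured steps that bear on this are the halogenated phenyl exchanges on the same carbonyl carbon. The step of a 1.9-fold higher number from compound 2 to compound 3 (0.27 log units; within the scatter) moves from the 2-chlorophenyl of compound 2 to a 4-bromophenyl and gives the largest movement seen, yet stays within the scatter; the step of a 1.4-fold lower number from compound 1 to compound 2 (0.14 log units; within the scatter) and the step of a 1.4-fold higher number from compound 1 to compound 3 (0.13 log units; within the scatter) are smaller still. Nothing seen here suggests that a fourth halogenated phenyl would break this pattern, so the step of a 1.5-fold higher number from compound 2 to compound 4 (0.19 log units; within the scatter) is expected to stay within the scatter, with a slight lean toward a higher number as for compound 3. Compound 4 is therefore estimated at 75000 nM, with a range from 30000 nM to 180000 nM.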

Compound 4, half-maximal inhibitory concentration: 43400 nM
Estimate against measurement, compound 4: 1.7-fold (0.24 log units) above; the range from low to high includes it.
By their numbers in this assay, from the lowest: compounds 4, 2, 1 and 3 (each within the scatter of the next, the first and the last beyond it).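

In this assay, among the compounds shown here, the exchange of fluoro for bromo on an aromatic carbon gives the only step in this set to pass the scatter: a 2.1-fold lower number from compound 3 to compound 4 (0.32 log units; beyond the scatter). The halogen on this phenyl group therefore has some bearing on the number, although the step is modest and rests on this one pair. For the compounds shown here, the other new steps, a 1.1-fold lower number from compound 2 to compound 4 (0.05 log units; within the scatter) and a 1.6-fold lower number from compound 1 to compound 4 (0.19 log units; within the scatter), lie within the scatter, so the 4-fluorophenyl of compound 4 cannot be told apart from the 2-chlorophenyl of compound 2 or the 3-chlorophenyl of compound 1, and no information at hand accounts for the one step that passes it.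

On these data alone, every group on this carbonyl carbon is a halogenated phenyl, so it remains open whether an unsubstituted phenyl, a 4-chlorophenyl, a 4-methoxyphenyl or a 4-aminophenyl would follow the same narrow spread. Also open, as far as these compounds go, is whether a carboxylic acid or an amine on that ring, or any change to the shared core, would move the number further than these halogen exchanges do.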